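The source may hold more compounds than are shown below. What is called first, only, known or untested is meant among the compounds shown, and "the series" means these compounds.

Values so far in a functional assay on HeLa cells (Homo sapiens) for cytotoxicity, read by sulforhodamine B assay; on this read-out lower numbers stand for stronger inhibition and higher numbers for weaker inhibition
compound 1 `COc1ccc(S(=O)(=O)NC(C2=CC(=O)c3c(O)ccc(O)c3C2=O)C(C)C)cc1` gives 8950 nM
compound 2 `CC(C)C(NS(=O)(=O)c1ccc(F)cc1)C1=CC(=O)c2c(O)ccc(O)c2C1=O` gives 6650 nM
compound 3 `CC(C)C(NS(=O)(=O)c1cccc(Br)c1)C1=CC(=O)c2c(O)ccc(O)c2C1=O` gives 860 nM

Compound 2 sits with compound 1 at the upper end of these numbers, and the gap between them is small, a 1.3-fold lower number from compound 1 to compound 2 (0.13 log units; within the scatter). Compound 3 lies clearly lower than both.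

The next compound is compound 4 `CC(C)C(NS(=O)(=O)c1ccccc1Br)C1=CC(=O)c2c(O)ccc(O)c2C1=O`, which has 2-bromophenyl in place of 4-fluorophenyl on a sulfonyl sulfur.

For the measured compounds named here, two measured steps bear on this change. The closer one is a 7.7-fold lower number from compound 2 to compound 3 (0.89 log units; beyond the scatter), where 3-bromophenyl replaces the same 4-fluorophenyl on the sulfonyl sulfur. The other is a 10-fold lower number from compound 1 to compound 3 (1.02 log units; beyond the scatter), with 3-bromophenyl in place of 4-methoxyphenyl, and it points the same way. Going by the values given here, no measured compound carries 2-bromophenyl, so neither step transfers directly. A lower number in this assay is still expected, though by less than compound 3 showed, and with a wide margin that reaches back towards compound 2.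

The expected step is a 3.3-fold lower number from compound 2 to compound 4 (0.52 log units; beyond the scatter).

For compound 4 the estimated value is 2000 nM, with an expected range from 600 nM to 6500 nM.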

Compound 4, half-maximal inhibitory concentration: 8310 nM
Estimate against measurement, compound 4: 4.2-fold (0.62 log units) below; the measured number lies above the stated range.
By their numbers in this assay, from the lowest: compound 3; then compounds 2, 4 and 1 (each within the scatter of the next).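

In this assay, bromine on the phenyl group does not by itself go with the low number of compound 3: 2-bromophenyl in place of 3-bromophenyl on the sulfonyl sulfur gives a 9.7-fold higher number from compound 3 to compound 4 (0.99 log units; beyond the scatter), so these two bromophenyl compounds, which differ only in the printed position of the bromine, stand well apart. The 2-bromophenyl group also brings no measurable separation from the earlier sulfonamides, with a 1.2-fold higher number from compound 2 to compound 4 (0.10 log units; within the scatter) against 4-fluorophenyl and a 1.1-fold lower number from compound 1 to compound 4 (0.03 log units; within the scatter) against 4-methoxyphenyl, which leaves compounds 1, 2 and 4 together as one level and compound 3 alone below them. Nothing available explains why the two bromophenyl compounds part in this way.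

Still open, as far as these compounds go, is whether the low number belongs to bromine itself or would persist with chloro, methyl or an amine in place of the bromine of the 3-bromophenyl group. Also open, from the compounds shown here alone, is whether the gap between the 3-bromophenyl and 2-bromophenyl groups holds when a longer chain replaces the branched alkyl group of the shared core.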